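Swapping a methoxy for a methyl on the aryl piperazine

The source may hold more compounds than are shown below. What is called first, only, known or untested is meant among the compounds shown, and "the series" means these compounds.

Compound 1 `CSc1ccccc1N1CCN(CCCNc2ncccc2C(=O)N(C)C)CC1`: 0.631 nM
Compound 2 `COc1ccc(N2CCN(CCCNc3ncccc3C(=O)N(C)C)CC2)c(OC)c1`: 31.6 nM

In a functional assay for antagonist activity at Alpha-1A adrenergic receptor (Oryctolagus cuniculus) (a lower number here means tighter binding, a higher number weaker binding), compound 2 carries the highest of the two numbers, and its nearest neighbour is compound 1, with a 50-fold higher number from compound 1 to compound 2 (1.70 log units; beyond the scatter) separating them. Compound 3 `COc1cc(C)ccc1N1CCN(CCCNc2ncccc2C(=O)N(C)C)CC1` is the next compound: methyl in place of methoxy on an aromatic carbon, which read one bond further out is 2,4-dimethoxyphenyl to 2-methoxy-4-methylphenyl. Among the compounds with values here, the only measured step replaced the whole aryl group, so it says little about this smaller change. Compound 3 is therefore expected to stay close to compound 2, with a 2.1-fold lower number from compound 2 to compound 3 (0.32 log units; beyond the scatter) at most modest, and its estimated value is 15 nM with a range from 4 nM to 60 nM.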

Compound 3, dissociation constant: 0.794 nM
Estimate against measurement, compound 3: 19-fold (1.28 log units) above; the measured number lies below the stated range.
By their numbers in this assay, from the lowest: compounds 1 and 3 (each within the scatter of the next); then compound 2.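

In this assay, methyl in place of methoxy on this aromatic carbon, para to a large group, gives a 40-fold lower number from compound 2 to compound 3 (1.60 log units; beyond the scatter), so this one exchange alone is enough for a large step, which the earlier replacement of the whole aryl group could not show. The 2-methoxy-4-methylphenyl and 2-(methylsulfanyl)phenyl groups then read alike, with a 1.3-fold higher number from compound 1 to compound 3 (0.10 log units; within the scatter). Nothing available here accounts for this difference.

On these data alone, whether the drop follows from methyl itself or from the loss of methoxy remains open. So does how a chlorine, an ethyl or a hydroxyl would read on this carbon.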